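Urea series: aryl swap on the urea nitrogen

A few compounds are considered here, and "the series" means these few. Any claim that something is new, unique, unknown or untested is made for them only; others in the source may bear on it.

Working notes on a urea series read in a functional assay on CRL2813 cells (Homo sapiens) for cytotoxicity, read by sulforhodamine B assay, with a stated time of 5 days; a lower number here means a stronger inhibitor, a higher number a weaker inhibitor.

Among the compounds with values here, compound 1 `O=C(Nc1ccc(Br)cc1)N[C@H]1CC[C@H](Oc2ccc(F)cc2)CC1` gives only a limit in this assay, > 20000 nM, and this is where it stands among the numbers so far. That point sits at the limit of > 20000 nM in this assay, at which 1 of the 2 values shown sits. A second compound with a different core, compound 2 `O=C(Nc1cccc(C(F)(F)F)c1)N[C@H]1CCC[C@H](Oc2ccc(C(F)(F)F)cc2)C1`, gives 3800 nM in this assay. No direct comparison between compound 1 and compound 2 is drawn here, and their two values are taken only as they stand.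

The change from compound 1 to compound 3 `O=C(Nc1cccc(Cl)c1)N[C@H]1CC[C@H](Oc2ccc(F)cc2)CC1` is 3-chlorophenyl in place of 4-bromophenyl on an amide-type nitrogen. Within the data shown here, no measured pair follows this change, and the starting point is a limit, so the size of the step can only be guessed. The expected step is an at least 1.3-fold lower number from compound 1 to compound 3 (0.12 log units; that floor lies within the scatter), a modest move toward stronger inhibition that may still end within reach of the limit. Compound 3 is therefore estimated at 15000 nM in this assay, with a range from 5000 nM to 40000 nM.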

Compound 3, half-maximal inhibitory concentration: 5900 nM
Beside the measured number, compound 3's estimate is 2.5-fold (0.41 log units) above it, within the range that was stated.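

Changing the aryl group on the amide-type nitrogen registers in this assay: 3-chlorophenyl in place of 4-bromophenyl gives an at least 3.3-fold lower number from compound 1 to compound 3 (0.53 log units; beyond the scatter), so this position responds with the rest of the core of compound 1 held fixed. With compound 3 at 5900 nM, this core now has a readable number in this assay. Compound 1 stands at a limit and not a number, so the step has a floor but no known full size: the limit of > 20000 nM in this assay, at which 1 of the 3 values shown sits.

The halogen and its place on the ring change together here, and the compounds shown do not separate the two, since neither 3-bromophenyl nor 4-chlorophenyl is among them on this core. From the compounds shown here alone, how an amine or a carboxylic acid on this aryl ring would read in this assay also remains open.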